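Pyrimidinyl in place of phenyl on the shared core

The source may hold more compounds than are shown below. What is called first, only, known or untested is meant among the compounds shown, and "the series" means these compounds.

Compound 1 `CC(C)(C)c1ccc(NC(=O)c2ccc(-c3ccccc3)cc2)cc1` and compound 2 `CC(C)(C)c1ccc(NC(=O)c2ccc(-c3cccnc3)cc2)cc1` share a core and differ only in the group carried on an aromatic carbon. In a functional assay on Dorsal root ganglion for antagonist activity at transient receptor potential cation channel subfamily V member 1 (Rattus norvegicus) (a higher number here means a weaker inhibitor, a lower number a stronger inhibitor), compound 1 gives 3600 nM, the highest of the two numbers available, and compound 2 gives 1300 nM. Among the compounds with values here, the single measured step, a 2.8-fold lower number from compound 1 to compound 2 (0.44 log units; beyond the scatter), is modest but beyond the scatter. Compound 3 `CC(C)(C)c1ccc(NC(=O)c2ccc(-c3cncnc3)cc2)cc1` is not yet measured; it differs from compound 1 by pyrimidin-5-yl in place of phenyl on an aromatic carbon, one ring nitrogen further than the change seen in compound 2. Within the data shown here, only the step of a 2.8-fold lower number from compound 1 to compound 2 (0.44 log units; beyond the scatter) bears on this; nothing shows what the second nitrogen adds. Because compound 2 gives 1300 nM, a lowering of similar size is expected for compound 3, a 4.0-fold lower number from compound 1 to compound 3 (0.60 log units; beyond the scatter). Compound 3 is estimated at 900 nM, with a range of 300 nM to 2700 nM.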

Compound 3, half-maximal inhibitory concentration: 10000 nM
Compound 3: middle estimate off by 11-fold (1.05 log units), on the low side; measured number above the stated range.
By their numbers in this assay, from the lowest: compound 2; then compound 1; then compound 3.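

In this assay, ring nitrogen at this position does not push the number in one direction: pyrimidin-5-yl in place of phenyl gives a 2.8-fold higher number from compound 1 to compound 3 (0.44 log units; beyond the scatter) and so runs opposite to the change to pyridin-3-yl. The step to the second nitrogen, a 7.7-fold higher number from compound 2 to compound 3 (0.89 log units; beyond the scatter), more than cancels the gain seen with compound 2, so the lowering with pyridin-3-yl does not carry over to pyrimidin-5-yl. Nothing available accounts for this reversal.

Still open, going by these compounds, is whether the placement of a single ring nitrogen matters, as pyridin-2-yl and pyridin-4-yl would show, and whether pyrazin-2-yl behaves like pyrimidin-5-yl. Also open, on these data alone, is whether an amine or a methoxy group on the pyrimidin-5-yl ring would change the picture.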